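This account rests on a few compounds, and the source may have more. Where it says the series, first, only, none or still open, it means among the compounds named here.

Among the measured compounds shown here, in a functional assay on cells for agonist activity at Free fatty acid receptor 1 (Homo sapiens), read by FLIPR and calcium flux (a higher number here means a larger maximal response, a lower number a smaller maximal response), compound 3 `Cc1ccc(Cl)c(COc2ccc(CCC(=O)O)cc2C)c1` reaches 243%, the highest of the three numbers measured so far. Compound 2 `Cc1cc(CCC(=O)O)ccc1OCc1ccccc1Cl` gives 80%, and compound 1 `O=C(O)CCc1ccc(OCc2ccccc2SC(F)(F)F)cc1` gives 74%; both lie far below compound 3, beyond the scatter. For the measured compounds named here, only one pair of measured compounds differs in a single place: the step is a number 163 percentage points higher from compound 2 to compound 3 (beyond the scatter), a methyl in place of hydrogen on an aromatic carbon.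

Compound 4 `Cc1ccc(OC(C)C)c(COc2ccc(CCC(=O)O)cc2C)c1` has not yet been measured in this assay. Going by the values given here, it differs from compound 3 in one place: isopropoxy in place of chloro on an aromatic carbon None of the measured compounds shows a chloro exchanged for an isopropoxy, nor any exchange at all at that carbon, so the single known step, which concerns a methyl in place of hydrogen, does not bear on this change. Among the compounds with values here, the only anchor is compound 3 itself, whose maximal response of 243% is the starting point. Without a comparable step, the direction of the change is open, and the large spread between compound 3 and the other two compounds argues for a wide range. Compound 4 is therefore expected to give about 180%, within a range from 90% to 260%. This estimate amounts to an expected step of a number 63 percentage points lower from compound 3 to compound 4 (beyond the scatter), which could fall either way.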

Compound 4, largest response reached (reported as percent of maximum), in percent of the reference or control that the assay uses: 154%
Estimate against measurement, compound 4: 26 percentage points above; low and high end bracket the measured number.
By their numbers in this assay, from the lowest: compounds 1 and 2 (each within the scatter of the next); then compound 4; then compound 3.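

In this assay, among the compounds shown here, the step of a number 89 percentage points lower from compound 3 to compound 4 (beyond the scatter) is the first exchange seen at this aromatic carbon, which sits ortho to a large group and para to a methyl group, and it shows that the maximal response depends on what is attached there. The exchange replaces a single chlorine atom with an isopropoxy group of 4 heavy atoms, including 1 hydrogen-bond acceptor, and the response drops by a large amount, yet compound 4 still gives 154% in this series, so the change lowers the response without abolishing it. No measurement is available that explains this drop.

From the compounds shown here alone, with only chloro and isopropoxy seen at this carbon, it remains open whether a methoxy group, which also attaches through oxygen but has a shorter chain, or a bromine atom would give a response closer to that of compound 3. Going by these compounds, it is also open whether the large gain from the added methyl group on the ring, seen between compounds 2 and 3, would carry over when isopropoxy takes the place of chloro.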